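This account rests on a few compounds, and the source may have more. Where it says the series, first, only, none or still open, it means among the compounds named here.

Measured compounds in an assay on HEK293 cells for inhibition of sodium- and chloride-dependent glycine transporter 1 (Homo sapiens), read by scintillation proximity assay; on this read-out higher numbers stand for weaker inhibition and lower numbers for stronger inhibition:
compound 1 `O=C(CN(C(=O)c1ccc(Cl)cc1)C1CCCCC1)Nc1cc(F)cc(F)c1`, giving 631 nM
compound 2 `O=C(CN(C(=O)C1CCOCC1)C1CCCCC1)Nc1cc(F)cc(F)c1`, giving 5010 nM
compound 3 `O=C(CN(C(=O)C1CCCCC1)C1CCCCC1)Nc1cc(F)cc(F)c1`, giving 6310 nM

Compound 3 stands at the highest number of the three; the nearer step up to it reads a 1.3-fold higher number from compound 2 to compound 3 (0.10 log units; within the scatter), the further step up to it reads a 10-fold higher number from compound 1 to compound 3 (1.00 log units; beyond the scatter). Compound 4 `Cn1ccc(C(=O)N(CC(=O)Nc2cc(F)cc(F)c2)C2CCCCC2)n1` differs from compound 3 by 1-methyl-1H-pyrazol-3-yl in place of cyclohexyl on a carbonyl carbon. The measured steps that bear on this are the two moves away from the 4-chlorophenyl of compound 1, a 10-fold higher number from compound 1 to compound 3 (1.00 log units; beyond the scatter) and a 7.9-fold higher number from compound 1 to compound 2 (0.90 log units; beyond the scatter), both swapping an aromatic ring for a non-aromatic ring on the same carbonyl carbon and both beyond the scatter. Compound 4 goes the other way, non-aromatic to aromatic, though with a five-membered ring carrying two hetero atoms rather than the 4-chlorophenyl of compound 1, so a smaller step toward lower numbers is expected, estimated as a 2.5-fold lower number from compound 3 to compound 4 (0.40 log units; beyond the scatter). Compound 4 is therefore expected at 2500 nM, within 800 nM to 8000 nM.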

Compound 4, half-maximal inhibitory concentration: > 25100 nM
Compound 4: no number, only a limit; the forecaster's own chance of this, stated with the estimate: 5%; at least 10-fold (1.00 log units) between middle value and limit.
By their numbers in this assay, from the lowest: compound 1; then compounds 2 and 3 (each within the scatter of the next). At a limit, above all of these: compound 4.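

In this assay compound 4 carries only a limit of the assay, not a number: the limit of > 25100 nM in this assay, at which 1 of the 4 values shown sits. An aromatic ring on this carbonyl carbon is thus not enough to reach the low number of compound 1, and compound 4 goes against any link between aromatic rings and lower numbers here (an at least 39-fold higher number from compound 1 to compound 4 (1.59 log units; beyond the scatter)). The 1-methyl-1H-pyrazol-3-yl also reads worse than either non-aromatic ring (an at least 3.9-fold higher number from compound 3 to compound 4 (0.59 log units; beyond the scatter); an at least 5.0-fold higher number from compound 2 to compound 4 (0.69 log units; beyond the scatter)).

Going by these compounds, whether a plain phenyl or a pyridyl on this carbonyl carbon would come close to compound 1 stays open, leaving the share of the chlorine unsettled. On these data alone, how far the true value of compound 4 lies past its limit is also open.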